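This account rests on a few compounds, and the source may have more. Where it says the series, first, only, none or still open, it means among the compounds named here.

Three compounds share one core and differ only in the group on the amide-type nitrogen. In a functional assay on CHO cells for antagonist activity at Orexin receptor type 2 (Homo sapiens), read by FLIPR and calcium flux (on this read-out lower numbers stand for stronger inhibition and higher numbers for weaker inhibition), compound 1 `COc1ccc(C)cc1NC(=O)CSc1nnc(-c2ccoc2C)n1Cc1ccco1` gives 15.9 nM, compound 2 `Cc1occc1-c1nnc(SCC(=O)Nc2ccc(F)c(Cl)c2)n1Cc1ccco1` gives 39.8 nM, and compound 3 `Cc1occc1-c1nnc(SCC(=O)Nc2cccc(F)c2)n1Cc1ccco1` gives 501 nM. Compound 2 thus holds the middle place of the three, set by a 2.5-fold higher number from compound 1 to compound 2 (0.40 log units; beyond the scatter) and by a 13-fold higher number from compound 2 to compound 3 (1.10 log units; beyond the scatter). Compound 4 `Cc1occc1-c1nnc(SCC(=O)Nc2cccc(Cl)c2)n1Cc1ccco1` differs from compound 2 by hydrogen in place of fluoro on an aromatic carbon. Among the measured compounds shown here, no measured step removes a fluoro alone; the steps that bear on it are a 13-fold higher number from compound 2 to compound 3 (1.10 log units; beyond the scatter), in which the chloro left while the fluoro stayed, and a 32-fold higher number from compound 1 to compound 3 (1.50 log units; beyond the scatter). Since compound 4 keeps the chloro whose departure gave a 13-fold higher number from compound 2 to compound 3 (1.10 log units; beyond the scatter), only a small loss is expected, a 1.6-fold higher number from compound 2 to compound 4 (0.20 log units; within the scatter). Compound 4 is therefore estimated at 63 nM, between 25 nM and 160 nM.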

Compound 4, inhibition constant: 63.1 nM
Compound 4: the middle estimate sits 1.0-fold (0.00 log units) below what was measured, within the range that was stated.
By their numbers in this assay, from the lowest: compound 1; then compounds 2 and 4 (each within the scatter of the next); then compound 3.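

Compound 2 and compound 4 cannot be told apart (a 1.6-fold higher number from compound 2 to compound 4 (0.20 log units; within the scatter)), so the fluoro of the 3-chloro-4-fluorophenyl group carries little weight on its own at this position. The chloro counts for far more (a 7.9-fold lower number from compound 3 to compound 4 (0.90 log units; beyond the scatter)), though 3-chlorophenyl still falls short of 2-methoxy-5-methylphenyl (a 4.0-fold higher number from compound 1 to compound 4 (0.60 log units; beyond the scatter)). No measurement at hand explains these steps. Still open, on these data alone, is how a bromo, a nitrile or an amine would fare in place of the chloro, and whether the methoxy or the methyl of compound 1 matters more.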